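The source may hold more compounds than are shown below. What is called first, only, known or untested is meant among the compounds shown, and "the series" means these compounds.

Two analogues have so far been run in a functional assay on P815 cells (Mus musculus) for antiproliferative activity; on this read-out higher numbers stand for weaker inhibition and lower numbers for stronger inhibition. Compound 1 `Nc1ccn([C@@H]2O[C@H](CO)[C@H](F)[C@H]2O)c(=O)n1` gives 21 ug/mL, while compound 2 `Nc1nc(=O)n(C2OC(CO)C(Cl)C2O)cc1F` gives 0.7 ug/mL, the lowest of the two numbers and beyond the scatter from compound 1. The next analogue, compound 3 `Nc1nc(=O)n(C2OC(CO)C(Br)C2O)cc1F`, differs from compound 2 only by bromo in place of chloro on a saturated ring carbon. Going by the values given here, no measured pair isolates such a change, so there is no precedent here to draw on. The step from compound 2 to compound 3 is expected to be small, no change at the digits printed from compound 2 to compound 3 (within the scatter), in no particular direction and not beyond the scatter. For compound 3 the estimated value is 0.7 ug/mL, with a range from 0.3 ug/mL to 2 ug/mL.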

Compound 3, concentration for 50% inhibition: 0.2 ug/mL
For compound 3 the middle estimate is 3.5-fold (0.54 log units) above the measured one, outside the stated range (below it).
By their numbers in this assay, from the lowest: compound 3; then compound 2; then compound 1.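

In this assay, going by these compounds alone, the halogen on this saturated ring carbon is not interchangeable: bromo in place of chloro gives a 3.5-fold lower number from compound 2 to compound 3 (0.54 log units; beyond the scatter), the first step that isolates this position. A single-atom exchange, with no change in hydrogen-bond donors, acceptors or net charge, is therefore enough to shift the read-out. Nothing at hand explains the step.

Going by these compounds, whether iodo, an amine or a methoxy group at this carbon would extend the step remains open. Compound 1 differs from compound 2 in more than one place, so the fluoro group cannot be ranked against chloro or bromo.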